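This account rests on a few compounds, and the source may have more. Where it says the series, first, only, none or still open, it means among the compounds named here.

Measured in a physicochemical assay for solubility; on this read-out higher numbers stand for higher solubility and lower numbers for lower solubility:
Compound 1 `CNC(=O)c1cc(C(=O)N[C@H]2[C@@H]3COC[C@@H]32)cc2c1OC[C@H]2c1cccnc1`: >= 104 ug/mL
Compound 2 `CNC(=O)c1cc(C(=O)N[C@H]2[C@@H]3C[C@@H](O)C[C@@H]32)cc2c1OC[C@H]2c1ccccc1`: >= 124 ug/mL
Compound 3 `CNC(=O)c1cc(C(=O)N[C@H]2C[C@@H]2C)cc2c1OC[C@@]2(C)c1ccccc1`: 3 ug/mL

Two of these three entries are limits of the assay, not numbers. Compound 1 sits at one such limit, >= 104 ug/mL. Compound 2 sits at the other, >= 124 ug/mL, so its true position is not known. Only compound 3 has a plain number, 3 ug/mL.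

The step followed here leads from compound 2 to compound 4 `CNC(=O)c1cc(C(=O)NCCC[C@H]2OC[C@H](N)CO2)cc2c1OC[C@H]2c1ccccc1`, which has not yet been measured. The change is a group of 10 heavy atoms (7 carbon, 1 nitrogen, 2 oxygen; one six-membered non-aromatic ring with 2 hetero atoms) in place of a group of 7 heavy atoms (6 carbon, 1 oxygen; one three-membered non-aromatic ring of carbon only, one five-membered non-aromatic ring of carbon only), on an amide-type nitrogen. Within the data shown here, no pair of measured compounds differs in one place only, so the size of this step has no direct precedent in these data. The expectation therefore rests on compound 2, with its limit of >= 124 ug/mL, and no change beyond the scatter is expected in either direction. The expected step is a step that the limit leaves unreadable from compound 2 to compound 4. For compound 4 the estimated value is 130 ug/mL, with an expected range from 50 ug/mL to 220 ug/mL.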

Compound 4, solubility: >= 153 ug/mL
Compound 4: a limit, no number; the forecaster's own chance of this, stated with the estimate: 65%; middle value at least 1.1-fold (0.07 log units) from the limit.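

In this assay compound 4 gives >= 153 ug/mL, which is a limit and not a number. The value of compound 2 is also a limit, so no step can be read between compound 2 and compound 4. The compounds shown leave open how far the exchange of groups on the amide-type nitrogen moves the read-out.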